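A few compounds are considered here, and "the series" means these few. Any claim that something is new, unique, unknown or untested is made for them only; others in the source may bear on it.

Measured compounds in this series:

- compound 1 `O=C1OC(c2ccnc3ccccc23)CN1C1CCN(Cc2cc3ccccc3[nH]2)CC1`: in an in vitro functional assay on RBL cells for antagonist activity at C-C chemokine receptor type 8 (Homo sapiens), read by FLIPR and calcium flux (on this read-out lower numbers stand for stronger inhibition and higher numbers for weaker inhibition), compound 1 gives 1000 nM
- compound 2 `O=C1OC(c2ccncc2)CN1C1CCN(Cc2cc3ccccc3[nH]2)CC1`: compound 2 gives only a limit of the assay, < 50200 nM
- compound 3 `COc1ccc2nccc(C3CN(C4CCN(Cc5c[nH]c6ccccc56)CC4)C(=O)O3)c2c1`: compound 3 likewise gives only a limit, < 50200 nM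

Compound 3 therefore stands at a limit and not at a number; the same holds for compound 2, as summarised by the limit of < 50200 nM in this assay, at which 2 of the 3 values shown sit. Among the compounds with values here, the one change with two measured ends, a step that the limit leaves unreadable from compound 1 to compound 2, is itself left unreadable by that limit, so no measured step gives a readable size.

Compound 4 `COc1ccc2nccc(C3CN(C4CCN(Cc5ccccc5Cl)CC4)C(=O)O3)c2c1` is not yet measured. It differs from compound 3 by 2-chlorophenyl in place of 1H-indol-3-yl on a saturated chain carbon bound to an amine nitrogen in a ring. No measured pair shares this change, so the size of the step from compound 3 to compound 4 cannot be read from the shown values, and only the number for compound 1, which keeps the (1H-indol-3-yl)methyl group, is a firm point of reference. With that, compound 4 is expected at 3000 nM, within 300 nM to 30000 nM, and the estimated step is a step that the limit leaves unreadable from compound 3 to compound 4; a further limit rather than a number is also a real possibility.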

Compound 4, half-maximal inhibitory concentration: < 50200 nM
Compound 4: no number, only a limit; the forecaster's own chance of this, stated with the estimate: 40%; the middle value does not contradict the limit.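

Compound 3 and compound 4 yield no new readable step, as each gives only a limit of the assay: the limit of < 50200 nM in this assay, at which 3 of the 4 values shown sit.

The compounds shown leave open how 2-chlorophenyl and 1H-indol-3-yl compare at this place on the shared core, since neither compound gives a number.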